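The source may hold more compounds than are shown below. What is called first, only, known or untested is meant among the compounds shown, and "the series" means these compounds.

Measured compounds

Compound 1, `N#Cc1c(-c2ccccc2O)c(C#N)c(=O)n(/N=C/c2cn(-c3ccccc3)nc2-c2ccccc2)c1N`: in an ADME assay on HeLa cells (Homo sapiens) for cytotoxicity, read by MTT assay (a lower number here means a stronger inhibitor, a higher number a weaker inhibitor), compound 1 gives > 200 ug/mL, a limit of the assay rather than a number.
Compound 2, `N#Cc1c(-c2ccccc2Cl)c(C#N)c(=O)n(/N=C/c2cn(-c3ccccc3)nc2-c2ccccc2)c1N`: in this assay compound 2 gives > 200 ug/mL, again a limit.
Compound 3, `N#Cc1c(-c2cccc(F)c2)c(C#N)c(=O)n(/N=C/c2cn(-c3ccccc3)nc2-c2ccccc2)c1N`: in this assay compound 3 gives > 200 ug/mL, also a limit.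

Compound 3 therefore stands at the same limit as the other two; there is no number that sets it apart from them. The three compounds share one core and differ only in the aryl group on one aromatic carbon of that core. The steps a step that the two limits leave unreadable from compound 1 to compound 3 and a step that the two limits leave unreadable from compound 2 to compound 3, like a step that the two limits leave unreadable from compound 1 to compound 2, cannot be sized, because of the limit of > 200 ug/mL in this assay, at which 3 of the 3 values shown sit.

Compound 4, `COc1cc(-c2c(C#N)c(N)n(/N=C/c3cn(-c4ccccc4)nc3-c3ccccc3)c(=O)c2C#N)cc(OC)c1OC`, is built the same way. The change is 3,4,5-trimethoxyphenyl in place of 3-fluorophenyl on an aromatic carbon. The measured steps that bear on it are the two that end at compound 3, and both are unreadable, so they give no direction and no size. All that can be said is that three different aryl groups on this carbon have all stayed at the limit. On that basis the expected step that the limit leaves unreadable from compound 3 to compound 4 is none beyond the scatter. For compound 4 the estimate in this assay is 250 ug/mL, with a range from 100 ug/mL to 600 ug/mL, most likely again reported only as a limit.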

Compound 4, half-maximal inhibitory concentration: > 200 ug/mL
Compound 4: a limit, no number (the forecaster's own chance of this, stated with the estimate: 80%); the middle value does not contradict the limit.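

In this assay compound 4 gives > 200 ug/mL, again a limit and not a number. No step from compound 1, compound 2 or compound 3 to compound 4 can be read: the limit of > 200 ug/mL in this assay, at which 4 of the 4 values shown sit.

The compounds shown leave open whether changing the aryl group on this carbon of the shared core alters the result in this assay at all, in either direction.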